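Swapping a methylpiperidine for a fused pyrrole-piperazine ring

This account rests on a few compounds, and the source may have more. Where it says the series, first, only, none or still open, it means among the compounds named here.

Compound 1, `COc1ccc2[nH]c(C(=O)N3CC(=O)N(Cc4ccccc4)[C@@H](CN4CCC(C)CC4)C3)cc2c1`: 93100 nM
Compound 2, `COc1ccc2[nH]c(C(=O)N3CC(=O)N(Cc4ccccc4)[C@@H](CN4CCN(Cc5ccccn5)CC4)C3)cc2c1`: > 100000 nM

For the measured compounds named here, in a physicochemical assay for solubility, read by spectrophotometry, in phosphate buffer, with a stated time of 2 h, at pH 7.4 (a higher number here means a more soluble compound, a lower number a less soluble compound), compound 1 gives 93100 nM, the only plain number among the two values shown. Compound 2 sits at a limit of the assay, > 100000 nM, which is where one of the two values stands (the limit of > 100000 nM in this assay, at which 1 of the 2 values shown sits). Compound 3, `COc1ccc2[nH]c(C(=O)N3CC(=O)N(Cc4ccccc4)[C@@H](CN4CCn5cccc5C4)C3)cc2c1`, differs from compound 1 by a group of 9 heavy atoms (7 carbon, 2 nitrogen; one five-membered aromatic ring with 1 hetero atom, one six-membered non-aromatic ring with 2 hetero atoms) in place of a group of 7 heavy atoms (6 carbon, 1 nitrogen; one six-membered non-aromatic ring with 1 hetero atom), on a saturated chain carbon bound to a saturated ring carbon. Going by the values given here, no measured step between two compounds exists here, so nothing points to a shift beyond the scatter in this assay in either direction. Compound 3 is expected to give about 95000 nM, within 45000 nM to 200000 nM. The expected step of a 1.0-fold higher number from compound 1 to compound 3 (0.01 log units; within the scatter) is small.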

Compound 3, solubility: 29700 nM
Compound 3: middle estimate off by 3.2-fold (0.50 log units), on the high side, and the stated range ends above it.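

In this assay, the place on a saturated chain carbon bound to a saturated ring carbon now has its first readable step: replacing 4-methylpiperidin-1-yl with the group carrying a five-membered aromatic ring gives a 3.1-fold lower number from compound 1 to compound 3 (0.50 log units; beyond the scatter) as the change. The group at this place can therefore move the reading beyond the usual scatter. Nothing measured here tells which feature of the entering group lies behind this change.

Still open, from the compounds shown here alone, is how a morpholine ring or a plain dimethylamino group at this place would read. So is whether the five-membered ring must be aromatic, which a saturated pyrrolidine ring could test.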